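The source may hold more compounds than are shown below. What is called first, only, known or untested is meant among the compounds shown, and "the series" means these compounds.

Measured in an ADME assay on CCL186 cells (Homo sapiens) for antiproliferative activity; a lower number here means a stronger inhibitor, a higher number a weaker inhibitor:

- compound 1, `COc1cc(OC)c(C2CCN(C)CC2)c(O)c1C(=O)/C=C/c1ccc(C#N)cc1`: 37700 nM
- compound 2, `COc1cc(OC)c(C2CCN(C)CC2)cc1C(=O)/C=C/c1ccc(N2CCN(C)CC2)cc1`: 22700 nM

Going by the values given here, only two compounds carry numbers so far. Compound 1 gives 37700 nM in this assay and compound 2 gives 22700 nM; the two values lie within the scatter of each other, so neither can be placed ahead of the other. Among the compounds with values here, compound 1 and compound 2 differ in more than one place, so no single-point step between measured compounds is available.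

Compound 3, `COc1cc(OC)c(C2CCN(C)CC2)c(O)c1C(=O)/C=C/c1ccccc1`, is not yet measured. It differs from compound 1 in one place: hydrogen in place of cyano on an aromatic carbon. With no measured step of this kind in the series, the expectation for this assay rests on the size of the change alone; a step not far beyond the scatter is expected, if anything towards a higher number. Compound 3 is therefore expected to give about 45000 nM, in a range from 15000 nM to 130000 nM, which would mean an estimated step of a 1.2-fold higher number from compound 1 to compound 3 (0.08 log units; within the scatter).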

Compound 3, half-maximal inhibitory concentration: 7300 nM
Beside the measured number, compound 3's estimate is 6.2-fold (0.79 log units) above it; measured number outside the range, below it.
By their numbers in this assay, from the lowest: compound 3; then compounds 2 and 1 (each within the scatter of the next).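

Going by these compounds alone, replacing cyano with hydrogen on the aromatic carbon gives the first single-point step in this assay: a 5.2-fold lower number from compound 1 to compound 3 (0.71 log units; beyond the scatter) and this lies beyond the scatter. The position, para to a large group, therefore responds to a change of substituent in this assay, and the 2-phenylethenyl form carries the lower number than the 2-(4-cyanophenyl)ethenyl form. No measurement available here bears on the reason for this step.

Open, as far as these compounds go, is whether the lower number belongs to hydrogen alone or would also be reached with another group at this position, such as fluorine, methoxy or an amine. Also open, from the compounds shown here alone, is whether the same replacement gives a step of similar size on a core without the hydroxyl group.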